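Acid-to-amide swap on the naphthyl acrylate series

The source may report more compounds than this note shows. Statements on the series, on what has been measured and on what is new or still open speak of the compounds shown alone.

Three compounds share a pyridine-acrylate core carrying an aryl group, differing in the aryl group and in the terminal carbonyl substituent. In an assay on a protein complex for inhibition of CDK8/Cyclin C (Homo sapiens), with a stated time of 1 h (on this read-out lower numbers stand for stronger inhibition and higher numbers for weaker inhibition), compound 2 `O=C(O)/C=C/c1ccncc1-c1ccc2ccccc2c1` gives 5 nM, the lowest of the three numbers. Going by the values given here, the ethyl ester compound 1 `CCOC(=O)/C=C/c1ccncc1-c1ccc2c(cnn2C)c1` gives 102 nM in this assay, and the ethyl ester compound 3 `CCOC(=O)/C=C/c1ccncc1-c1ccc2c(ccn2C)c1` gives 144 nM, both beyond the scatter from compound 2; as these two carry a different aryl group as well as a different carbonyl substituent, no single-change step links them to compound 2.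

Compound 4 `CN(C)C(=O)/C=C/c1ccncc1-c1ccc2ccccc2c1` differs from compound 2 by dimethylamino in place of hydroxy on a carbonyl carbon. Among the compounds with values here, no measured pair shows this change, so the expected step is read loosely from the esters: compound 1 at 102 nM and compound 3 at 144 nM both sit well above compound 2. A loss of potency beyond the scatter is expected, of the size an 8.0-fold higher number from compound 2 to compound 4 (0.90 log units; beyond the scatter). For compound 4 the estimated value in this assay is 40 nM, with a range from 8 nM to 200 nM.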

Compound 4, half-maximal inhibitory concentration: 30.1 nM
For compound 4 the middle estimate is 1.3-fold (0.12 log units) above the measured one; low and high end bracket the measured number.
By their numbers in this assay, from the lowest: compound 2; then compound 4; then compounds 1 and 3 (each within the scatter of the next).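

Going by these compounds alone, this is the first single-change step: at the carbonyl carbon, dimethylamino in place of hydroxy gives a 6.0-fold higher number from compound 2 to compound 4 (0.78 log units; beyond the scatter) in this assay. The position therefore responds to this change, but the step is modest, and the carboxy group can give way to dimethylcarbamoyl with the loss limited to that size. No measurement shown explains the loss of potency.

This one pair cannot separate the removal of the hydroxy hydrogen-bond donor from the entry of a larger group, and an amino or methylamino group on the same carbonyl carbon would bear on that question. On these data alone, whether the step carries over to the aryl groups of compound 1 and compound 3 also remains open.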